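The source may report more compounds than this note shows. Statements on the series, on what has been measured and on what is new or still open speak of the compounds shown alone.

Among the measured compounds shown here, in a physicochemical assay for lipophilicity, read by HPLC, at pH 7.5 (on this read-out lower numbers stand for lower lipophilicity and higher numbers for higher lipophilicity), three compounds have numbers so far. Compound 1 (`CCOc1ccccc1-c1ccc(-c2nc3cncc(Cl)c3c(N[C@H](CC)C(N)=O)c2C#N)cc1`) gives 3.7 and compound 2 (`CC[C@@H](Nc1c(C#N)c(-c2ccc(-c3cccc(Cl)c3F)cc2)nc2cnccc12)C(N)=O`) gives 3.1 while compound 3 (`CCOc1ccccc1-c1ccc(-c2nc3cnccc3c(N)c2C#N)cc1`) gives 3 as its reading. Compound 2 thus sits level with compound 3 within the scatter and well under compound 1 beyond it. Compared with compound 2, compound 4 (`CC[C@@H](Nc1c(C#N)c(-c2ccc(-c3cccc(CO)c3)cc2)nc2cnccc12)C(N)=O`) has 3-(hydroxymethyl)phenyl in place of 3-chloro-2-fluorophenyl on an aromatic carbon para to a large group. For the measured compounds named here, no measured pair differs in one place only, so no measured step can serve as a guide. The entering group carries a hydrogen-bond donor and acceptor and the leaving group neither, so a fall beyond the scatter is expected, an estimated a number 1.10 log units lower from compound 2 to compound 4 (beyond the scatter) in this assay for this change. Compound 4 is therefore expected at 2 within an estimated range from 1.6 to 2.5 on that reading.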

Compound 4, distribution coefficient: 2
Beside the measured number, compound 4's estimate shows no gap at the digits printed, and the stated range covers the measured number.
By their numbers in this assay, from the lowest: compound 4; then compounds 3 and 2 (each within the scatter of the next); then compound 1.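

In this assay, among the compounds shown here, putting 3-(hydroxymethyl)phenyl in place of 3-chloro-2-fluorophenyl gives a number 1.10 log units lower from compound 2 to compound 4 (beyond the scatter), the first measured step between compounds that differ in one place only. It shows that the read-out responds strongly to the group on this aromatic carbon, even though both groups have the same count of heavy atoms. Nothing shown here accounts for the size of this step.

This one step does not separate the loss of the chlorine and fluorine from the gain of the hydroxymethyl. A plain phenyl at this place could help separate them. Going by these compounds, how an aminomethyl or carboxylic acid group there would read is also open.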